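Sulfonyl aryl groups: the step to compound 3

The source may report more compounds than this note shows. Statements on the series, on what has been measured and on what is new or still open speak of the compounds shown alone.

In a functional assay on LNCaP cells (Homo sapiens) for antiproliferative activity, read by propidium iodide staining, with a stated time of 96 h (on this read-out higher numbers stand for weaker inhibition and lower numbers for stronger inhibition), compound 1 `CC(O)(CS(=O)(=O)c1cccc(C(F)(F)F)c1)C(=O)Nc1ccc(S(F)(F)(F)(F)F)cc1` gives 21000 nM and compound 2 `CC(O)(CS(=O)(=O)c1ccccc1C(F)(F)F)C(=O)Nc1ccc(S(F)(F)(F)(F)F)cc1` gives 10800 nM. Within the data shown here, these are the only two numbers so far, and they lie within the scatter of each other, so compound 2 holds no real rank over compound 1.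

Compound 3 `CC(O)(CS(=O)(=O)c1cccc(OC(F)(F)F)c1)C(=O)Nc1ccc(S(F)(F)(F)(F)F)cc1` is still unmeasured. It keeps the shared core and carries 3-(trifluoromethoxy)phenyl in place of 2-(trifluoromethyl)phenyl on a sulfonyl sulfur.

Among the measured compounds shown here, the one measured step bearing on this change is a 1.9-fold lower number from compound 1 to compound 2 (0.29 log units; within the scatter), with 2-(trifluoromethyl)phenyl in place of 3-(trifluoromethyl)phenyl on the sulfonyl sulfur, and it stays within the scatter. For the measured compounds named here, no measured compound carries a trifluoromethoxy group, so the guidance is thin. Resting on compound 2 with 10800 nM and on that small step, no change beyond the scatter is expected in this assay, in either direction.

The estimate means an expected 1.3-fold higher number from compound 2 to compound 3 (0.11 log units; within the scatter). Compound 3 is estimated at 14000 nM, with an expected range of 5500 nM to 36000 nM.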

Compound 3, half-maximal inhibitory concentration: 21700 nM
Beside the measured number, compound 3's estimate is 1.6-fold (0.19 log units) below it, within the range that was stated.
By their numbers in this assay, from the lowest: compounds 2, 1 and 3 (each within the scatter of the next).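

In this assay, trifluoromethoxy in place of trifluoromethyl on an aromatic carbon gives a 1.0-fold higher number from compound 1 to compound 3 (0.01 log units; within the scatter), so the oxygen that enters with this group leaves the read-out effectively where it stood for that pair. The other new step, 3-(trifluoromethoxy)phenyl in place of 2-(trifluoromethyl)phenyl on a sulfonyl sulfur, gives a 2.0-fold higher number from compound 2 to compound 3 (0.30 log units; within the scatter), which means that all three pairs among these aryl groups now lie within the scatter and this position has yet to give a real separation, even with a change of both substituent and its place on the ring. Nothing available on these compounds offers an explanation for this flat result.

As far as these compounds go, all three compounds carry a fluorinated substituent on the sulfonyl aryl group, so it remains open whether an amine or a carboxylic acid on that ring, or a longer chain in place of the aryl group on the sulfonyl sulfur, would produce a step beyond the scatter. The compounds shown also leave open whether an unsubstituted phenyl on the sulfonyl sulfur would fall within the same narrow band.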